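Replacing a Small Carbamate with a Longer Ester Chain

This account rests on a few compounds, and the source may have more. Where it says the series, first, only, none or still open, it means among the compounds named here.

Of the compounds shown here, three have been tested in a functional assay on HEL cells (Homo sapiens) for cytotoxicity, read by microscopy; a higher number here means that more compound is tolerated, a lower number that less compound is tolerated. Compound 1 `CC(=O)NC1=CS(=O)(=O)O[C@@]12[C@@H](CO[Si](C)(C)C(C)(C)C)O[C@@H](n1cc(C)c(=O)n(C)c1=O)[C@@H]2O[Si](C)(C)C(C)(C)C` reaches only a limit of the assay, >= 80000 nM. Compound 2 `Cc1cn([C@@H]2O[C@@H]3COC(=O)[C@]3(OS(C)(=O)=O)[C@H]2O)c(=O)[nH]c1=O` likewise gives only a limit, >= 400000 nM. Compound 3 `COC(=O)NC1=CS(=O)(=O)O[C@@]12[C@@H](CO[Si](C)(C)C(C)(C)C)O[C@@H](n1cc(C)c(=O)n(C)c1=O)[C@@H]2O[Si](C)(C)C(C)(C)C` also stands at a limit, >= 50000 nM, as recorded in the limit of >= 50000 nM in this assay, at which 1 of the 3 values shown sits. Going by the values given here, the single step between related compounds, a step that the two limits leave unreadable from compound 1 to compound 3, cannot be read in size, since both ends are limits rather than numbers.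

Compound 4 `Cc1cn([C@@H]2O[C@H](CO[Si](C)(C)C(C)(C)C)[C@@]3(OS(=O)(=O)C=C3NCCC(=O)OCc3ccccc3)[C@H]2O[Si](C)(C)C(C)(C)C)c(=O)n(C)c1=O` differs from compound 3 in one place: 2-(benzyloxycarbonyl)ethyl in place of methoxycarbonyl on an amine nitrogen. Among the compounds with values here, no measured step shows what such a change does to cytotoxicity, and every value so far sits at a limit, so no tolerance threshold has yet been crossed by any compound.

The step of a number no higher from compound 3 to compound 4 (the limit leaves the size open) is therefore expected to remain within the scatter. Compound 4 is estimated at 50000 nM, with a range from 15000 nM to 150000 nM, and most likely again a limit rather than a number.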

Compound 4, minimum cytotoxic concentration: >= 400000 nM
Compound 4: no number, only a limit; the forecaster's own chance of this, stated with the estimate: 75%; middle value at least 8.0-fold (0.90 log units) away from the limit.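

Compound 4 also gives only a limit in this assay, >= 400000 nM. The steps to compound 4 from compound 1 and from compound 3 therefore cannot be read in size. The compounds shown leave open at what concentration, if any, each one becomes toxic to these cells.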